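Swapping the 2-aminoethoxy Group of Compound 3

The compounds below may be only part of what the source reports. "The series", "measured", "known", "first", "only" and "open" are said of these compounds alone.

In an ADME assay on microsomes from liver (Homo sapiens) for metabolic stability, read by LC-MS, tested at 1 uM (a higher number here means faster removal of the compound, a lower number slower removal), compound 3 `NCCOc1ccc([C@H]2CC[C@]3(CC2)OOC2(O3)C3CC4CC(C3)CC2C4)cc1` gives < 7 mL.min-1.g-1, which is a limit of the assay and not a number. Compound 2 `NCCCOc1ccc([C@H]2CC[C@]3(CC2)OOC2(O3)C3CC4CC(C3)CC2C4)cc1`, with 3-aminopropoxy in that place, gives < 7 mL.min-1.g-1, also a limit. Among the compounds with values here, compound 1 `O=S(=O)(c1ccc([C@H]2CC[C@]3(CC2)OOC2(O3)C3CC4CC(C3)CC2C4)cc1)N1CCNCC1`, with (piperazin-1-yl)sulfonyl there, gives 16 mL.min-1.g-1, the only true number so far. The data therefore show (the limit of < 7 mL.min-1.g-1 in this assay, at which 2 of the 3 values shown sit).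

Compound 4 `NC(=O)C1CCN(Cc2ccc([C@H]3CC[C@]4(CC3)OOC3(O4)C4CC5CC(C4)CC3C5)cc2)CC1` carries (4-carbamoylpiperidin-1-yl)methyl in place of 2-aminoethoxy on the same aromatic carbon: (4-carbamoylpiperidin-1-yl)methyl in place of 2-aminoethoxy on an aromatic carbon. Within the data shown here, no measured step makes this exact exchange. The closest guides are changes of the group at this place, namely an at least 2.2-fold lower number from compound 1 to compound 2 (0.35 log units; beyond the scatter) and an at least 2.2-fold lower number from compound 1 to compound 3 (0.35 log units; beyond the scatter). These show that the read-out in this assay can move with this group, although only compound 1 gives a true number. The remaining comparison, a step that the two limits leave unreadable from compound 2 to compound 3, adds nothing on size.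

A small upward move is therefore expected, perhaps not beyond the scatter, and compound 4 may also stay at the limit. The expected change is an at least 1.4-fold higher number from compound 3 to compound 4 (0.15 log units; that floor lies within the scatter). Compound 4 is estimated at 10 mL.min-1.g-1, with an expected range from 5 mL.min-1.g-1 to 30 mL.min-1.g-1.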

Compound 4, intrinsic clearance in microsomes: 10 mL.min-1.g-1
Compound 4: middle estimate and measured number agree at the digits printed, within the range that was stated.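

In this assay, compound 4 gives the second true number at this aromatic carbon, so the position now has two readable values, each from a group with a six-membered non-aromatic ring. Against the other readable compound the result is a 1.6-fold lower number from compound 1 to compound 4 (0.20 log units; within the scatter), so exchanging (piperazin-1-yl)sulfonyl for (4-carbamoylpiperidin-1-yl)methyl produces no clear difference in clearance, even though the two groups are built quite differently. Against the two chains ending in an amine, the steps are an at least 1.4-fold higher number from compound 3 to compound 4 (0.15 log units; that floor lies within the scatter) and an at least 1.4-fold higher number from compound 2 to compound 4 (0.15 log units; that floor lies within the scatter), and both are only floors, which by themselves do not establish a real rise over the compounds with 2-aminoethoxy and 3-aminopropoxy.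

As far as these compounds go, the true distance from compound 2 and compound 3 to compound 4 stays open, as neither of the first two gives more than a limit: the limit of < 7 mL.min-1.g-1 in this assay, at which 2 of the 4 values shown sit. Also open is which part of the new group matters for clearance, for instance what a carboxylic acid in place of the carbamoyl, or a plain piperidine without it, would do.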